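The compounds below may be only part of what the source reports. "The series", "measured", "known", "first", "only" and "open" are said of these compounds alone.

Of the compounds shown here, three built on one shared core have been tested in an ADME assay on HeLa cells (Homo sapiens) for cytotoxicity, read by ATP content, with a stated time of 3 days; a higher number here means that more compound is tolerated, a lower number that less compound is tolerated. Compound 1 `N#CCCCn1c(Cn2c(=O)n(-c3ncco3)c3ccncc32)cc2cc(Cl)ccc21` carries a 1,3-oxazol-2-yl group on an aromatic nitrogen; in this assay compound 1 gives > 50000 nM, which is a limit of the assay rather than a number. Compound 2 `N#CCCCn1c(Cn2c(=O)n(-c3ccc(C(=O)O)cc3)c3ccncc32)cc2cc(Cl)ccc21` carries a 4-carboxyphenyl group at that nitrogen, and in this assay compound 2 gives > 50000 nM, again a limit. Compound 3 `COc1ccc(-n2c(=O)n(Cc3cc4cc(Cl)ccc4n3CCCC#N)c3cnccc32)c(F)c1` carries a 2-fluoro-4-methoxyphenyl group there, and in this assay compound 3 gives > 50000 nM, also a limit. Compound 3 thus stands exactly where the other two stand, at the limit of > 50000 nM in this assay, at which 3 of the 3 values shown sit.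

Compound 4 `N#CCCCn1c(Cn2c(=O)n(-c3ccc(OC(F)(F)F)cc3)c3ccncc32)cc2cc(Cl)ccc21` is not yet measured and differs from compound 3 in one place: 4-(trifluoromethoxy)phenyl in place of 2-fluoro-4-methoxyphenyl on an aromatic nitrogen. The measured steps that bear on this change are a step that the two limits leave unreadable from compound 1 to compound 3 and a step that the two limits leave unreadable from compound 2 to compound 3, together with a step that the two limits leave unreadable from compound 1 to compound 2; none of them has a readable size, and none points in any direction. Going by the values given here, with every value so far sitting at the limit, compound 4 is expected to give 50000 nM, with a range from 20000 nM to 100000 nM. This estimate means a number no higher from compound 3 to compound 4 (the limit leaves the size open), nothing beyond the scatter.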

Compound 4, half-maximal cytotoxic concentration: > 50000 nM
Compound 4: only a limit was reported (the forecaster's own chance of this, stated with the estimate: 85%); the middle value sits exactly at the limit.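

Compound 4 gives > 50000 nM, which is a limit and not a number. Going by these compounds alone, no step from compound 1, compound 2 or compound 3 to compound 4 can be read: the limit of > 50000 nM in this assay, at which 4 of the 4 values shown sit. The compounds shown leave open at what concentration any of them harms these cells, and whether the group on the aromatic nitrogen changes that concentration.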